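Iodo in Place of Trifluoromethyl: Compound 4 Awaits Its Number

The source may report more compounds than this note shows. Statements on the series, on what has been measured and on what is new or still open speak of the compounds shown alone.

Of the compounds shown here, three sharing one core have so far been tested in a functional assay on HEL cells (Homo sapiens) for cytotoxicity, read by microscopy; a lower number here means a stronger inhibitor, a higher number a weaker inhibitor. Compound 1 `O=C1O/C(=C\Cn2cc(C(F)(F)F)c(=O)[nH]c2=O)C(OCc2ccccc2)=C1OCc1ccccc1` gives 2000 nM in this assay, the lowest of the three numbers. Compound 2 `O=C1O/C(=C\Cn2cc(Br)c(=O)[nH]c2=O)C(OCc2ccccc2)=C1OCc1ccccc1` gives 5000 nM, and compound 3 `O=C1O/C(=C\Cn2cnc3c(-n4cccc4)ncnc32)C(OCc2ccccc2)=C1OCc1ccccc1`, which carries a wholly different heteroaromatic arm, gives 20000 nM, the highest of the set. Going by the values given here, the one measured step that connects neighbours differing in a single place is a 2.5-fold higher number from compound 1 to compound 2 (0.40 log units; beyond the scatter), a modest worsening that lies beyond the scatter.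

The next compound, compound 4 `O=C1O/C(=C\Cn2cc(I)c(=O)[nH]c2=O)C(OCc2ccccc2)=C1OCc1ccccc1`, differs from compound 1 as follows: iodo in place of trifluoromethyl on an aromatic carbon. This change bears most directly on the step from compound 1 to compound 2, since in both cases the trifluoromethyl leaves and a halogen of one heavy atom enters on the same aromatic carbon. Compound 2 showed a rise of a 2.5-fold higher number from compound 1 to compound 2 (0.40 log units; beyond the scatter), and the account expects that compound 4 will move in the same direction by a similar, modest amount, though the scatter could mask part of it. Compound 4 is therefore estimated at 4500 nM in this assay, within a range of 2000 nM to 10000 nM, which corresponds to an expected step of a 2.3-fold higher number from compound 1 to compound 4 (0.35 log units; beyond the scatter).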

Compound 4, half-maximal inhibitory concentration: 5000 nM
Compound 4: middle estimate off by 1.1-fold (0.05 log units), on the low side, within the range that was stated.
By their numbers in this assay, from the lowest: compound 1; then compounds 2 and 4 (each within the scatter of the next); then compound 3.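

In this assay, iodo in place of trifluoromethyl gives a 2.5-fold higher number from compound 1 to compound 4 (0.40 log units; beyond the scatter), a step of the same printed size as the one seen with bromo (a 2.5-fold higher number from compound 1 to compound 2 (0.40 log units; beyond the scatter)), so the higher number on leaving trifluoromethyl no longer rests on a single replacement. Iodo in place of bromo gives no change at the digits printed from compound 2 to compound 4 (within the scatter), which means that on this aromatic carbon the two halogens cannot be told apart in this assay, while compound 1, with its trifluoromethyl, keeps a number lower than both beyond the scatter. Nothing shown accounts for why the two halogens read alike or why trifluoromethyl stands apart from them.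

The compounds shown leave open whether chloro, fluoro, methyl, a nitrile or an amine on this same carbon would read with trifluoromethyl or with bromo and iodo. They also leave open whether the gap between trifluoromethyl and the halogens would persist if the benzyl groups on the shared core gave way to plain methyl groups.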